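The source may report more compounds than this note shows. Statements on the series, on what has been measured and on what is new or still open speak of the compounds shown alone.

Working notes on the series. Compound 1 `COc1ccc2[nH]c(C(=O)N3CC(=O)N(Cc4ccccc4)[C@@H](CN4CCCCC4)C3)cc2c1` is the reference point. In a physicochemical assay for solubility, read by spectrophotometry, in phosphate buffer, with a stated time of 2 h, at pH 7.4 (on this read-out lower numbers stand for lower solubility and higher numbers for higher solubility), compound 1 gives > 25000 nM, which is a limit of the assay and not a number. Where compound 1 stands is therefore known only as the limit of > 25000 nM in this assay, at which 1 of the 2 values shown sits. Compound 2 `COc1ccc2[nH]c(C(=O)N3CC(=O)N(Cc4ccccc4)[C@@H](CN4CCN(S(=O)(=O)c5ccccc5)CC4)C3)cc2c1` carries a different group on the saturated chain carbon, and in this assay compound 2 gives 16900 nM. Of this pair only the two values themselves are shown; no step between them is counted here. Compound 3 `COc1ccc2[nH]c(C(=O)N3CC(=O)N(Cc4ccccc4)[C@@H](CN4CC5CCCCC5C4)C3)cc2c1` is not yet measured in this assay. It differs from compound 1 in one place: a group of 9 heavy atoms (8 carbon, 1 nitrogen; one five-membered non-aromatic ring with 1 hetero atom, one six-membered non-aromatic ring of carbon only) in place of a group of 6 heavy atoms (5 carbon, 1 nitrogen; one six-membered non-aromatic ring with 1 hetero atom), on a saturated chain carbon bound to a saturated ring carbon. For the measured compounds named here, no measured step in this set speaks to the size of such a change, so the expectation rests on the reading of compound 1 alone, which sits at the limit. The step of an at least 2.0-fold lower number from compound 1 to compound 3 (0.31 log units; beyond the scatter) is expected to run downward by a moderate amount, beyond the scatter but not far beyond it. For compound 3 the estimate in this assay is 12000 nM, with a range from 4000 nM to 35000 nM, and a real chance remains that only a limit is reported.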

Compound 3, solubility: 23800 nM
Compound 3: the middle estimate sits 2.0-fold (0.30 log units) below what was measured; the measured number falls inside the stated range.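

For the compounds shown here, on the saturated chain carbon bound to a saturated ring carbon, this assay gives the first step for a ring change, the group of 9 heavy atoms entering where piperidin-1-yl leaves: an at least 1.0-fold lower number from compound 1 to compound 3 (0.02 log units; that floor lies within the scatter). Compound 3 gives 23800 nM, a true number, so the larger group with two rings, which has the same counts of hydrogen-bond donors and acceptors and no net charge, still gives a measured reading at this position. The step shows only a floor that does not separate from the scatter. For compound 1 the reading is a limit of the assay and not a number, and the true size of the step cannot be read: the limit of > 25000 nM in this assay, at which 1 of the 3 values shown sits.

From the compounds shown here alone, it remains open whether a carboxylic acid, a morpholin-4-yl group or an open-chain amine on this saturated chain carbon would give a step beyond the scatter from compound 1. Going by these compounds, how far the value of compound 1 lies past its limit also stays open, and the size of the step with it.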